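The source may hold more compounds than are shown below. What is called first, only, known or untested is meant among the compounds shown, and "the series" means these compounds.

Working notes on the series, measured in a functional assay on A549 cells (Homo sapiens) for antiproliferative activity, read by MTT assay, with a stated time of 48 h; a higher number here means a weaker inhibitor, a lower number a stronger inhibitor.

Of the compounds shown here, two carry numbers so far. Compound 1 `CCCCNc1ccc2ncnc(Nc3cccc(Cl)c3)c2c1` gives 4010 nM in this assay. Compound 2 `O=C(/C=C/c1cccc(Br)n1)Nc1ccc2ncnc(Nc3cccc(Cl)c3)c2c1` gives 4160 nM in this assay. The two numbers sit within the scatter of each other, so compound 2 stands alongside compound 1 rather than apart from it; the butylamino chain of compound 1 and the acrylamide with the 6-bromopyridin-2-yl group in compound 2 lead to the same range of activity.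

Compound 3 `Cc1cccc(/C=C/C(=O)Nc2ccc3ncnc(Nc4cccc(Cl)c4)c3c2)n1` is not yet measured. It differs from compound 2 in one place: methyl in place of bromo on an aromatic carbon. Within the data shown here, no measured pair covers a change of this kind, so nothing here says how methyl in place of bromo on that aromatic carbon should shift this assay. The expectation is a step from compound 2 to compound 3 of a 1.0-fold lower number from compound 2 to compound 3 (0.02 log units; within the scatter), none beyond the scatter in either direction. Compound 3 is therefore estimated at 4000 nM in this assay, with a range from 1500 nM to 11000 nM.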

Compound 3, half-maximal inhibitory concentration: 2160 nM
The estimate for compound 3 lay 1.9-fold (0.27 log units) above the measured number, within the range that was stated.
By their numbers in this assay, from the lowest: compounds 3, 1 and 2 (each within the scatter of the next).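

Moving from 6-bromopyridin-2-yl to 6-methylpyridin-2-yl gives the first pair in the series that differs in one place, and in this assay the step reads a 1.9-fold lower number from compound 2 to compound 3 (0.28 log units; within the scatter) for this exchange of one heavy atom for another. At this position, next to the ring nitrogen, this assay therefore does not separate bromo from methyl. No measurement at hand bears on why the two groups fall so close together.

Going by these compounds, it remains open whether a different group at the same place, such as an amine, a carboxylic acid or a longer chain, would give a step beyond the scatter. Also open, on these data alone, is what the 2-(6-methylpyridin-2-yl)ethenyl part contributes as a whole, which a plain ethyl link in place of the ethenyl link would begin to test.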